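The source may report more compounds than this note shows. Statements on the series, on what has been measured and on what is new or still open speak of the compounds shown alone.

Compound 1 `C=CS(=O)(=O)N1CCN(c2ncnc3sc(-c4ccc(C(F)(F)F)cc4)cc23)CC1`: 7080 nM
Compound 2 `C=CS(=O)(=O)N1CCN(c2ncnc3sc(-c4cccc5ccccc45)cc23)CC1`: 28100 nM
Compound 3 `C=CS(=O)(=O)N1CCN(c2ncnc3sc(-c4ccc(OC)nc4)cc23)CC1`: 11900 nM

These numbers come from a functional assay on MDA-MB-436 cells (Homo sapiens) for antiproliferative activity, read by MTT assay, with a stated time of 48 h; on this read-out lower numbers stand for stronger inhibition and higher numbers for weaker inhibition. Compound 3 sits at the low end of the three numbers, level with one neighbour: a 1.7-fold higher number from compound 1 to compound 3 (0.23 log units; within the scatter). Against the highest number the gap is clearer: a 2.4-fold lower number from compound 2 to compound 3 (0.37 log units; beyond the scatter).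

Compound 4 `C=CS(=O)(=O)N1CCN(c2ncnc3sc(-c4cc(Br)cnc4F)cc23)CC1` keeps the shared core and exchanges one group: 5-bromo-2-fluoropyridin-3-yl in place of 6-methoxypyridin-3-yl on an aromatic carbon. Here 5-bromo-2-fluoropyridin-3-yl takes the place of 6-methoxypyridin-3-yl, on an aromatic carbon next to the ring sulfur. All three measured steps change this same place, and the largest of them is a 4.0-fold higher number from compound 1 to compound 2 (0.60 log units; beyond the scatter), which is only a modest move. Among the measured compounds shown here, none of the measured compounds carries bromine or fluorine on a pyridine, so the direction of any change cannot be read from these data. In this assay, no step beyond the scatter is therefore expected, and the estimated step is a 1.1-fold lower number from compound 3 to compound 4 (0.03 log units; within the scatter). For compound 4 the expected value is 11000 nM, with an estimated range from 5000 nM to 26000 nM.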

Compound 4, half-maximal inhibitory concentration: 28400 nM
For compound 4 the middle estimate is 2.6-fold (0.41 log units) below the measured one, and the stated range ends below it.
By their numbers in this assay, from the lowest: compounds 1 and 3 (each within the scatter of the next); then compounds 2 and 4 (each within the scatter of the next).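

In this assay, exchanging one pyridine group for another at this position is not a neutral change: there is a 2.4-fold higher number from compound 3 to compound 4 (0.38 log units; beyond the scatter) even though the two groups have the same number of heavy atoms and the same kind of ring. What is attached to the pyridine therefore matters here, not just the presence of the ring. The result also places a single pyridine group level with the naphthalen-1-yl group (a 1.0-fold higher number from compound 2 to compound 4 (0.00 log units; within the scatter)), while the distance to the 4-(trifluoromethyl)phenyl compound is a 4.0-fold higher number from compound 1 to compound 4 (0.60 log units; beyond the scatter) and so matches the widest step seen so far. No measured evidence accounts for this change.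

Going by these compounds, the bromine and the fluorine enter together, so their separate contributions remain open. Also open, on these data alone, is how a pyridine carrying an amine or a carboxylic acid at this place would compare.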